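Chain length in the chloroacyl anilide sulfonate series

The source may hold more compounds than are shown below. What is called first, only, known or untested is meant among the compounds shown, and "the series" means these compounds.

Compound 1 `CC(C)c1ccccc1OS(=O)(=O)c1cccc(NC(=O)CCl)c1` carries the shortest chain of the set and in a functional assay on MCF7 cells (Homo sapiens) for antiproliferative activity, read by sulforhodamine B assay, with a stated time of 48 h (on this read-out higher numbers stand for weaker inhibition and lower numbers for stronger inhibition), compound 1 gives 2200 nM. Compound 2 `CC(C)c1ccccc1OS(=O)(=O)c1cccc(NC(=O)CCCl)c1` differs from it by chloromethyl in place of chloro on a saturated chain carbon bound to a carbonyl carbon, and in this assay compound 2 gives 12000 nM; the change amounts to a 5.5-fold higher number from compound 1 to compound 2 (0.74 log units; beyond the scatter). Compound 3 `CC(C)c1ccccc1OS(=O)(=O)c1ccc(NC(=O)CCCl)cc1` has the same chain as compound 2 on a differently substituted core; the difference between the two cores is not broken down here. In this assay compound 3 gives 9000 nM, which lies within the scatter of the number for compound 2 and is clearly weaker than the number for compound 1.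

Compound 4 `CC(C)c1ccccc1OS(=O)(=O)c1ccc(NC(=O)CCCCl)cc1` is not yet measured. It differs from compound 3 by chloromethyl in place of chloro on a saturated chain carbon, two bonds along the chain from a carbonyl carbon. This is the same kind of change as that from compound 1 to compound 2, but the place is not the same: there the chain carbon was bound to a carbonyl carbon, here it sits two bonds along the chain from a carbonyl carbon. Within the data shown here, the only measured step of this kind, from compound 1 to compound 2, lengthened the chain and weakened inhibition beyond the scatter. On that single precedent, a further weakening is expected for compound 4, estimated as a 2.2-fold higher number from compound 3 to compound 4 (0.35 log units; beyond the scatter), though a smaller one, since the second lengthening starts from a chain that is already longer. Compound 4 is therefore expected at about 20000 nM in this assay, estimated to lie between 7000 nM and 60000 nM.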

Compound 4, half-maximal inhibitory concentration: 5200 nM
Estimate against measurement, compound 4: 3.8-fold (0.59 log units) above; measured number below the stated range.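

In this assay, the step on the core of compound 3 is a 1.7-fold lower number from compound 3 to compound 4 (0.24 log units; within the scatter), so on this core the added chain carbon brings no change that stands clear of the scatter. The change therefore does not carry over in size from one core to the other, and the earlier step cannot be used as a guide to this one: the same change on two cores in this assay, a 5.5-fold higher number (0.74 log units; beyond the scatter) from compound 1 to compound 2 and a 1.7-fold lower number (0.24 log units; within the scatter) from compound 3 to compound 4, 9.4-fold (0.97 log units) apart, beyond the scatter of two such steps

What this does not show is the source of the gap: the two steps differ both in the core and in the place on the chain, and the four compounds do not separate the two, so the gap may belong to either or to both together.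

Still open, on these data alone, is how the (3-chloropropyl)carbonyl chain of compound 4 behaves on the core of compound 1, and how the shortest chain, that of compound 1, behaves on the core of compound 3, the two pieces that would set the same chain on both cores. Also open, as far as these compounds go, is what a longer chain, a bromo group in place of the terminal chloro, or a plain alkyl chain with no halogen would give on either core.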